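This account rests on a few compounds, and the source may have more. Where it says the series, first, only, none or still open, it means among the compounds named here.

Measured in a functional assay on brain (Rattus norvegicus, strain Wistar) for inhibition; on this read-out lower numbers stand for stronger inhibition and higher numbers for weaker inhibition:
Compound 1 `CCCCCCCCCCCCCCCCCCc1ccc(-c2c(C)[nH]c(=O)n2C)cc1`: > 100000 nM
Compound 2 `CCCCCCCCCCCCc1ccc(-c2c(C)[nH]c(=O)n2C2CCCCC2)cc1`: > 100000 nM

Both entries are limits of the assay and not numbers. Compound 2 gives only a limit, > 100000 nM. Compound 1 stands in the same position, so neither compound has a number that could place it. The evidence so far amounts to the limit of > 100000 nM in this assay, at which 2 of the 2 values shown sit.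

Compound 3 `CCCCCCCCCCCCCCCCCCc1ccc(-c2c(C)[nH]c(=O)n2C2CCCCC2)cc1` has yet to be measured. It differs from compound 2 by a single change: hexyl in place of hydrogen on a saturated chain carbon, ten or more bonds along the chain from an aromatic carbon. In words, this is hexyl in place of hydrogen on a saturated chain carbon, ten or more bonds along the chain from an aromatic carbon.

Among the compounds with values here, no measured step gauges a change of this kind, so the expectation is loose. In this assay, no shift beyond the scatter is expected, although a modest move toward stronger inhibition cannot be ruled out. This expectation rests on compound 2, whose limit is > 100000 nM. The expected size of the change is a number no higher from compound 2 to compound 3 (the limit leaves the size open). Compound 3 is estimated at 100000 nM, with an expected range of 20000 nM to 200000 nM.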

Compound 3, half-maximal inhibitory concentration: > 100000 nM
Compound 3 ended at the assay's limit; the forecaster's own chance of this, stated with the estimate: 75%; the middle value lies on the limit itself.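

In this assay compound 3 gives > 100000 nM, which is a limit of the assay and not a number. Within the data shown here, compound 1 and compound 2 also rest on limits, so no step to compound 3 can be read. The compounds shown leave open how strongly any of them inhibits and whether either change alters that, and the evidence remains: the limit of > 100000 nM in this assay, at which 3 of the 3 values shown sit.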